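Shortening the chain before a terminal phenyl ring

This account rests on a few compounds, and the source may have more. Where it says the series, first, only, none or still open, it means among the compounds named here.

Three amide-linked lactones carrying a long saturated chain that ends in an aromatic ring were tested in a functional assay on PC-3 cells (Homo sapiens) for cytotoxicity, read by sulforhodamine B assay, with a stated time of 5 days; on this read-out lower numbers stand for stronger inhibition and higher numbers for weaker inhibition. Compound 1 `O=C(CCCCCCCc1ccccc1)N[C@H]1CCOC1=O` gives 85000 nM in this assay. Compound 2 `O=C(CCCCCCCCCCc1ccccc1)N[C@H]1CCOC1=O` gives 66000 nM in this assay. Compound 3 `O=C(CCCCCCCCCCCc1ccccc1)N[C@H]1CCOC1=O` reaches only a limit of this assay, > 100000 nM. Compound 1 and compound 2 lie within the usual scatter of each other, so no order can be read between them.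

Among the compounds with values here, the one structural change measured here is phenyl in place of benzyl on a saturated chain carbon, ten or more bonds along the chain from a carbonyl carbon. It produced an at least 1.5-fold lower number from compound 3 to compound 2 (0.18 log units; that floor lies within the scatter). That size is only a floor because of the limit of > 100000 nM in this assay, at which 1 of the 3 values shown sits.

The unmeasured compound 4 `O=C(CCCCCCc1ccccc1)N[C@H]1CCOC1=O` is reached from compound 1 by the same kind of change, (phenyl in place of benzyl on a saturated chain carbon, six bonds along the chain from a carbonyl carbon). The place is not the same: the measured change sits farther along the chain from a carbonyl carbon than the change that leads to compound 4 does. How the core of compound 1 differs from the core of compound 3 is not broken down here.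

The step to compound 4 is expected to be a 1.2-fold higher number from compound 1 to compound 4 (0.07 log units; within the scatter), resting on the small size of an at least 1.5-fold lower number from compound 3 to compound 2 (0.18 log units; that floor lies within the scatter) in the measured pair. Compound 4 is therefore estimated at 100000 nM in this assay, with a likely span from 50000 nM to 200000 nM.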

Compound 4, half-maximal inhibitory concentration: > 100000 nM
Compound 4: no number, only a limit (the forecaster's own chance of this, stated with the estimate: 40%); the middle value lies on the limit itself.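

In this assay compound 4 gives > 100000 nM, which is a limit of the assay and not a number. The change of phenyl in place of benzyl on a saturated chain carbon, six bonds along the chain from a carbonyl carbon, can thus be read only as a floor, an at least 1.1-fold higher number from compound 1 to compound 4 (0.07 log units; that floor lies within the scatter). Read side by side, the two steps point in opposite directions, but each is only a floor within the scatter, so they show neither that the change carries over from one core to another nor that it fails to: the same change on two cores in this assay, an at least 1.5-fold lower number (0.18 log units; that floor lies within the scatter) from compound 3 to compound 2 and an at least 1.1-fold higher number (0.07 log units; that floor lies within the scatter) from compound 1 to compound 4; the limit leaves it open whether they differ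

The true size of each step remains open, and so does any order among the four chain lengths shown. Also open, going by these compounds, is how a much shorter chain, or an amine or a carboxylic acid in place of the phenyl ring that ends the chain, would read in this assay.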